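The source may report more compounds than this note shows. Statements on the series, on what has been measured and on what is new or still open speak of the compounds shown alone.

In a functional assay on A549 cells (Homo sapiens) for antiproliferative activity, read by MTT assay, with a stated time of 48 h (a higher number here means a weaker inhibitor, a lower number a stronger inhibitor), compound 1 (`Fc1ccc(-c2nn(-c3ccccc3)cc2-c2nc3cc(Cl)ccc3[nH]2)cc1`) gives 1320 nM and sits level with compound 2 (`Clc1ccc(-c2nn(-c3ccccc3)cc2-c2nc3cc(Cl)ccc3[nH]2)cc1`) at 1340 nM while compound 3 (`Cc1ccc2[nH]c(-c3cn(-c4ccccc4)nc3-c3ccc(Cl)cc3)nc2c1`) gives a clearly higher 4640 nM as its number. Compound 4 (`COc1ccc(-c2nn(-c3ccccc3)cc2-c2nc3cc(Cl)ccc3[nH]2)cc1`) is still unmeasured and differs from compound 2 by methoxy in place of chloro on an aromatic carbon in a swap of 4-chlorophenyl to 4-methoxyphenyl. At that same place, chloro in place of fluoro gave a 1.0-fold higher number from compound 1 to compound 2 (0.01 log units; within the scatter) as its result. Elsewhere on the molecule, methyl in place of chloro gave a 3.5-fold higher number from compound 2 to compound 3 (0.54 log units; beyond the scatter) as its result. Neither step brings in methoxy, so the guidance is loose, and a modest rise in this assay is expected. The expected change is a 1.9-fold higher number from compound 2 to compound 4 (0.27 log units; within the scatter) by this estimate. The estimated value for compound 4 is 2500 nM with an expected range from 1000 nM to 6000 nM as its bounds.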

Compound 4, half-maximal inhibitory concentration: 3130 nM
Estimate against measurement, compound 4: 1.3-fold (0.10 log units) below; measured number inside the range.
By their numbers in this assay, from the lowest: compounds 1 and 2 (each within the scatter of the next); then compounds 4 and 3 (each within the scatter of the next).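

Swapping one halogen for another at this place on the 4-chlorophenyl ring left the number unchanged, but methoxy moves it beyond the scatter, a modest weakening seen against both halogens: a 2.3-fold higher number from compound 2 to compound 4 (0.37 log units; beyond the scatter) and a 2.4-fold higher number from compound 1 to compound 4 (0.37 log units; beyond the scatter). So this position is not indifferent to what sits on it, even though the two halogens read alike. Nothing shown gives a reason for the rise. Still open, on these data alone, is how an amine or a hydroxyl group would read at this place, and whether a longer chain such as ethoxy would raise the number further.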